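The compounds below may be only part of what the source reports. "The series", "measured", "known", "first", "only" and "open" are said of these compounds alone.

Measured so far in an assay on CHO cells with metabotropic glutamate receptor 5 (Homo sapiens) as the target; a lower number here means that less compound is needed, a higher number that more compound is needed for the effect:
- compound 1 `O=C(Nc1cc(-c2ccccc2)nn1-c1ccccc1)c1ccc(F)c(F)c1` gives 10 nM
- compound 2 `O=C(Nc1cc(-c2ccccc2)nn1-c1ccccc1)c1cccc(Cl)c1` gives 40 nM
- compound 3 `O=C(Nc1cc(-c2ccccc2)nn1-c1ccccc1)c1ccccn1` gives 290 nM

Compound 3 stands highest of the three numbers in this assay. Its nearest neighbour is compound 2, and that gap reads a 7.3-fold higher number from compound 2 to compound 3 (0.86 log units; beyond the scatter); against compound 1 it reads a 29-fold higher number from compound 1 to compound 3 (1.46 log units; beyond the scatter). Compound 4 `Cc1ccccc1C(=O)Nc1cc(-c2ccccc2)nn1-c1ccccc1` has not been measured. Relative to compound 3 it carries 2-methylphenyl in place of pyridin-2-yl on a carbonyl carbon. The two steps that bear on this change are the two that put the pyridin-2-yl in place of a six-membered ring of carbon only: a 29-fold higher number from compound 1 to compound 3 (1.46 log units; beyond the scatter) and a 7.3-fold higher number from compound 2 to compound 3 (0.86 log units; beyond the scatter), both beyond the scatter and both towards a higher number. Among the compounds with values here, compound 4 runs that direction in reverse, back to a six-membered aromatic ring of carbon only, though substituted differently from the rings of compound 1 and compound 2, and no compound with a 2-methylphenyl there has been measured. The step of a 4.0-fold higher number from compound 1 to compound 2 (0.60 log units; beyond the scatter) shows that the substitution on the carbon ring itself shifts the number by a modest amount. For compound 4 a lower number than compound 3 is therefore expected, a step of about a 7.3-fold lower number from compound 3 to compound 4 (0.86 log units; beyond the scatter). The estimate for compound 4 in this assay is 40 nM, within 12 nM to 150 nM.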

Compound 4, half-maximal effective concentration: > 10000 nM
Compound 4: a limit, no number; the forecaster's own chance of this, stated with the estimate: 3%; middle value at least 250-fold (2.39 log units) from the limit.
By their numbers in this assay, from the lowest: compound 1; then compound 2; then compound 3. At a limit, above all of these: compound 4.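

In this assay compound 4 stands at a limit of the assay, not at a number: the limit of > 10000 nM in this assay, at which 1 of the 4 values shown sits. A six-membered aromatic ring of carbon only on this carbonyl carbon therefore does not by itself give a lower number than pyridin-2-yl: compound 1 and compound 2 follow that pattern, while compound 4 goes against it, with an at least 34-fold higher number from compound 3 to compound 4 (1.53 log units; beyond the scatter). The substitution on the carbon ring, which earlier moved the number only by a 4.0-fold higher number from compound 1 to compound 2 (0.60 log units; beyond the scatter), now proves to matter far more at this place, with an at least 250-fold higher number from compound 2 to compound 4 (2.39 log units; beyond the scatter) and an at least 1000-fold higher number from compound 1 to compound 4 (3.00 log units; beyond the scatter).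

Still open, from the compounds shown here alone, is whether an unsubstituted phenyl, a 3-methylphenyl or a 2-methoxyphenyl on this carbonyl carbon would stay near compound 2 or follow compound 4, so the series does not yet separate the methyl group from its place on the ring. Also open, going by these compounds, is how an amine or a carboxylic acid on the carbon ring would read in this assay.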